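This account rests on a few compounds, and the source may have more. Where it says the series, first, only, none or still open, it means among the compounds named here.

Two compounds of the series have numbers in a functional assay on T47D cells (Homo sapiens) for cytotoxicity, read by MTT assay, with a stated time of 48 h (on this read-out higher numbers stand for weaker inhibition and lower numbers for stronger inhibition), so far. Compound 1 `COc1cc(N2C(=S)SCC2(O)c2ccc(Br)cc2)cc(OC)c1OC` gives 16.3 ug/mL there. Compound 2 `COc1cc(-n2c(-c3ccc(F)cc3)csc2=S)cc(OC)c1OC` gives 38.9 ug/mL, the higher of the two numbers, with compound 1 as its nearest neighbour at a gap that lies beyond the scatter. Compound 3 `COc1cc(-n2c(-c3ccc(C)cc3)csc2=S)cc(OC)c1OC` differs from compound 2 by methyl in place of fluoro on an aromatic carbon. Among the measured compounds shown here, no measured pair shows this change, so no step beyond the scatter is expected in either direction. The estimate for compound 3 in this assay is 35 ug/mL, within 15 ug/mL to 80 ug/mL. The expected step of a 1.1-fold lower number from compound 2 to compound 3 (0.05 log units; within the scatter) is accordingly small.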

Compound 3, half-maximal inhibitory concentration: 16.3 ug/mL
Compound 3: middle estimate off by 2.1-fold (0.33 log units), on the high side, and the stated range covers the measured number.
By their numbers in this assay, from the lowest: compounds 1 and 3 (each within the scatter of the next); then compound 2.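

In this assay, among the compounds shown here, the change from 4-fluorophenyl to 4-methylphenyl gives the first comparison that differs in one place, and a 2.4-fold lower number from compound 2 to compound 3 (0.38 log units; beyond the scatter) is a modest step. This position, para to a large group, therefore does respond to a change of substituent, with methyl giving the stronger inhibition of this pair. Nothing available explains this step.

As far as these compounds go, it remains open whether an amine or a carboxylic acid at this place would move the number in the same direction. A longer chain, such as propyl, also remains untested against methyl in the compounds shown.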